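This account rests on a few compounds, and the source may have more. Where it says the series, first, only, none or still open, it means among the compounds named here.

Measured so far in a functional assay on A549 cells (Homo sapiens) for inhibition, read by sulforhodamine B assay, with a stated time of 72 h; on this read-out lower numbers stand for stronger inhibition of growth and higher numbers for weaker inhibition of growth:
compound 1, `CCOC(=O)/C=C/c1ccncc1-c1ccc2[nH]ccc2c1`: 7440 nM
compound 2, `CNC(=O)/C=C/c1ccncc1-c1ccc2[nH]ccc2c1`: > 10000 nM
compound 3, `CNC(=O)CCc1ccncc1-c1ccc2ccccc2c1`: 10400 nM

In this assay compound 3 gives 10400 nM, the higher of the two numbers read. Compound 1 stands nearest with 7440 nM, and the gap between them lies within the scatter, so no order can be drawn from it. For compound 2 this assay reports only a limit, > 10000 nM, and no number.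

Within the data shown here, one measured step touches the change that follows: an at least 1.3-fold higher number from compound 1 to compound 2 (0.12 log units; that floor lies within the scatter). Its size is known only as a floor, because that step ends at the limit of > 10000 nM in this assay, at which 1 of the 3 values shown sits.

Compound 4, `COC(=O)/C=C/c1ccncc1-c1ccc2ccccc2c1`, differs from compound 3 by 2-(methoxycarbonyl)ethenyl in place of 2-(methylcarbamoyl)ethyl on an aromatic carbon. This runs the ester-for-amide exchange of that measured step in the opposite direction and at the same time replaces the saturated chain by an ethenyl chain; the second part of the change has no measured counterpart among these compounds, and the core differs from that of compound 1.

The expectation for this assay is therefore a modest lowering of the number, a 1.6-fold lower number from compound 3 to compound 4 (0.20 log units; within the scatter), likely not beyond the scatter. For compound 4 the estimated value is 6500 nM, with a range from 2500 nM to 16000 nM.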

Compound 4, concentration for 50% growth inhibition: 760 nM
The estimate for compound 4 lay 8.6-fold (0.93 log units) above the measured number; the whole stated range lies above it.
By their numbers in this assay, from the lowest: compound 4; then compounds 1 and 3 (each within the scatter of the next).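

In this assay, the position on an aromatic carbon of a six-membered aromatic ring with 1 nitrogen, opposite the ring nitrogen, responds strongly to this change: a 14-fold lower number from compound 3 to compound 4 (1.14 log units; beyond the scatter). Compound 2 is reported only as a limit, so the one earlier step, which exchanged an ester for an amide on the core of compound 1, gives a floor within the scatter and no measure of how much this position can respond: the limit of > 10000 nM in this assay, at which 1 of the 4 values shown sits. Nothing shown bears on the cause of the new step, in which 2-(methoxycarbonyl)ethenyl replaces 2-(methylcarbamoyl)ethyl as a single exchange of the whole side chain.

The shares of the ester and of the ethenyl chain in this step remain unseparated; a methyl ester on the saturated chain, or a methylamide on the ethenyl chain, on the core of compound 3 would divide them. Also open, on these data alone, is how a carboxylic acid, a primary amide or a longer ester chain at this position would read in this assay, and whether the step carries over to the core of compound 1.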